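A few compounds are considered here, and "the series" means these few. Any claim that something is new, unique, unknown or untested is made for them only; others in the source may bear on it.

In an ADME assay on cells (Hepatocyte, Homo sapiens) for metabolic stability (on this read-out lower numbers stand for a shorter-lived compound and higher numbers for a longer-lived compound), the measured compounds stand as follows:

Compound 1 `O=C(OC1CCC(CN2CCN(c3cc(=O)c4cc(C(F)(F)F)cc([N+](=O)[O-])c4s3)CC2)CC1)c1ccncc1` gives 0.075 h
Compound 2 `Cc1ccc(C(=O)OC2CCC(CN3CCN(c4cc(=O)c5cc(C(F)(F)F)cc([N+](=O)[O-])c5s4)CC3)CC2)cc1` gives 0.148 h
Compound 3 `O=C(OC1CCC(CN2CCN(c3cc(=O)c4cc(C(F)(F)F)cc([N+](=O)[O-])c4s3)CC2)CC1)c1ccco1` gives 0.075 h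

Compound 3 at 0.075 h reads the same as compound 1, and all three values lie within the scatter of one another. Compound 4 `O=C(OC1CCC(CN2CCN(c3cc(=O)c4cc(C(F)(F)F)cc([N+](=O)[O-])c4s3)CC2)CC1)c1ccc(C(F)(F)F)cc1` carries 4-(trifluoromethyl)phenyl in place of furan-2-yl on a carbonyl carbon, in counts (4-(trifluoromethyl)phenyl in place of furan-2-yl on a carbonyl carbon). The closest measured change is a 2.0-fold lower number from compound 2 to compound 3 (0.30 log units; within the scatter), which runs from 4-methylphenyl to furan-2-yl. The other steps at this place are a 2.0-fold higher number from compound 1 to compound 2 (0.30 log units; within the scatter) and no change at the digits printed from compound 1 to compound 3 (within the scatter). None of these leaves the scatter, so no step beyond it is expected in this assay, though any small shift would be expected to be upward. The estimated step is a 1.3-fold higher number from compound 3 to compound 4 (0.12 log units; within the scatter) and no more. Compound 4 is expected at 0.1 h, with an estimated range of 0.05 h to 0.2 h.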

Compound 4, half-life: 0.117 h
Compound 4: the middle estimate sits 1.2-fold (0.07 log units) below what was measured; the measured number falls inside the stated range.
By their numbers in this assay, from the lowest: compounds 1, 3, 4 and 2 (each within the scatter of the next).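

In this assay, 4-(trifluoromethyl)phenyl on the carbonyl carbon gives a 1.6-fold higher number from compound 3 to compound 4 (0.19 log units; within the scatter) and a 1.6-fold higher number from compound 1 to compound 4 (0.19 log units; within the scatter) as its steps from the two heteroaromatic groups. Trifluoromethyl in place of methyl on an aromatic carbon gives a 1.3-fold lower number from compound 2 to compound 4 (0.10 log units; within the scatter) and is the first step here that keeps the six-membered carbon ring and alters only its substituent. All four groups at this place therefore remain within the scatter of one another, and nothing available gives a cause for these numbers. As far as these compounds go, whether a saturated group such as cyclohexyl, or an amine or carboxylic acid on the ring, would leave the scatter remains open.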